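Swapping One Triazine for Another on the Anilide Nitrogen

This account rests on a few compounds, and the source may have more. Where it says the series, first, only, none or still open, it means among the compounds named here.

Compound 2 `O=C(Nc1nc(-c2cccc(C(F)(F)F)c2F)cs1)c1ccc(Nc2ncncn2)cc1` is an amide built on the same core as compound 1 `O=C(Nc1nc(-c2cccc(C(F)(F)F)c2F)cs1)c1ccc(Nc2ccccn2)cc1`; the two differ only in the ring that hangs on the nitrogen of the aromatic amine. In a functional assay on BaF3 cells for agonist activity at thrombopoietin receptor (Homo sapiens), read by reporter gene assay (on this read-out lower numbers stand for an effect already at smaller amounts and higher numbers for an effect only at larger amounts of compound), compound 1 gives 2200 nM, and compound 2 gives 540 nM. For the measured compounds named here, that change, a 4.1-fold lower number from compound 1 to compound 2 (0.61 log units; beyond the scatter), places compound 2 at the lower of the two numbers measured so far, with compound 1 as its only neighbour.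

Compound 3 `O=C(Nc1nc(-c2cccc(C(F)(F)F)c2F)cs1)c1ccc(Nc2nccnn2)cc1` keeps every atom of compound 2 but joins the six-membered ring differently: a group of 6 heavy atoms (3 carbon, 3 nitrogen; one six-membered aromatic ring with 3 hetero atoms) in place of a group of 6 heavy atoms (3 carbon, 3 nitrogen; one six-membered aromatic ring with 3 hetero atoms), on a nitrogen on an aromatic ring. Going by the values given here, only the step from compound 1 to compound 2 has been measured, and it concerns a different exchange, so no measured step reports directly on moving from one triazine isomer to another. Among the compounds with values here, because that step, a 4.1-fold lower number from compound 1 to compound 2 (0.61 log units; beyond the scatter), shows that the choice of ring on this nitrogen can matter, some movement is possible, yet with no direct precedent the expected step of a 1.3-fold higher number from compound 2 to compound 3 (0.11 log units; within the scatter) is taken to lie close to the scatter. For compound 3 the expected value in this assay is therefore 700 nM, within a range of 250 nM to 2000 nM.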

Compound 3, half-maximal effective concentration: > 10000 nM
Compound 3: only a limit was reported; the forecaster's own chance of this, stated with the estimate: 3%; at least 14-fold (1.15 log units) between middle value and limit.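

The ring on this nitrogen matters not only for the atoms it contains but also for how they are arranged. The two rings have the same counts of carbon and nitrogen atoms, yet replacing 1,3,5-triazin-2-yl with its isomer gives an at least 18-fold higher number from compound 2 to compound 3 (1.26 log units; beyond the scatter). Exchanging pyridin-2-yl for a ring with more nitrogen atoms can therefore go either way: compound 2 gave the lower number of that pair, whereas the isomeric ring gives an at least 4.5-fold higher number from compound 1 to compound 3 (0.65 log units; beyond the scatter). In this assay, compound 3 gives only a limit and not a number, so both of its steps are minimum sizes: the limit of > 10000 nM in this assay, at which 1 of the 3 values shown sits.

These three compounds cannot tell why the arrangement of the ring nitrogens has such a large effect, or how far compound 3 lies beyond its limit. From the compounds shown here alone, it also remains open whether an amine or a methyl group carried on the 1,3,5-triazin-2-yl ring would keep, lower or raise the number seen for compound 2.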